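A Side Chain on the Amine of Compound 1

A few compounds are considered here, and "the series" means these few. Any claim that something is new, unique, unknown or untested is made for them only; others in the source may bear on it.

Three compounds have measured numbers in a functional assay on DU-145 cells (Homo sapiens) for cytotoxicity, read by trypan blue exclusion, with a stated time of 96 h; a higher number here means a weaker inhibitor, a lower number a stronger inhibitor. Compound 1 `COc1ccc(CS(=O)(=O)/C=C/c2cc(OC)c(OC)c(OC)c2)cc1N` gives 3000 nM and compound 2 `COc1ccc(CS(=O)(=O)/C=C/c2c(OC)cc(O)cc2OC)cc1[N+](=O)[O-]` gives 5000 nM, two values within the scatter of each other. Compound 3 `COc1cc(OC)c(/C=C/S(=O)(=O)Cc2ccc(Cl)c(N)c2)c(OC)c1` gives 10 nM, a far lower number and a gap well beyond the scatter. Compound 1 therefore stands level with compound 2 at the weak end of this small set.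

Going by the values given here, compound 4 `COC(=O)CNc1cc(CS(=O)(=O)/C=C/c2cc(OC)c(OC)c(OC)c2)ccc1OC` has no measurement yet. It differs from compound 1 by a single change: (methoxycarbonyl)methyl in place of hydrogen on a nitrogen on an aromatic ring. This places (methoxycarbonyl)methyl in place of hydrogen on a nitrogen on an aromatic ring, turning amino into ((methoxycarbonyl)methyl)amino.

Among the compounds with values here, no measured pair here differs in one place only, so the data do not show what such a change does. In this assay no shift beyond the scatter is expected, and the estimated step is no change at the digits printed from compound 1 to compound 4 (within the scatter). The expected range stays wide because compound 3 gives 10 nM, which shows how far numbers in this set can move. For compound 4 the estimated value is 3000 nM, with an expected range of 500 nM to 15000 nM.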

Compound 4, half-maximal inhibitory concentration: 75000 nM
Compound 4: middle estimate off by 25-fold (1.40 log units), on the low side; the whole stated range lies below it.
By their numbers in this assay, from the lowest: compound 3; then compounds 1 and 2 (each within the scatter of the next); then compound 4.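

In this assay, the amino nitrogen of compound 1 proves not to be a free place for added groups: (methoxycarbonyl)methyl in place of hydrogen on that nitrogen gives a 25-fold higher number from compound 1 to compound 4 (1.40 log units; beyond the scatter) and so a much weaker inhibitor. Going by these compounds alone, the earlier compounds could not show this, since no two of them differed in one place only, and this is the first single change in the set that can be read directly. Nothing available explains why this change weakens the compound so much.

As far as these compounds go, it remains open whether the loss comes with any group on this nitrogen or with this particular side chain. A plain methyl on the nitrogen, or a carboxylic acid in place of the methyl ester, would help to separate those two readings.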